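The compounds below may be only part of what the source reports. "The series", "measured", "known", "first", "only" and "open" are said of these compounds alone.

Measured compounds:
Compound 1 `COc1cc(-c2cccc3nc(-c4ccc(C)cc4)oc23)cc(OC)c1OC`: 1900 nM
Compound 2 `COc1cc(-c2cccc3nc(-c4cccc(O)c4)oc23)cc(OC)c1OC`: 1900 nM

In a functional assay on NCI-H460 cells (Homo sapiens) for antiproliferative activity, read by MTT assay, with a stated time of 48 h (a lower number here means a stronger inhibitor, a higher number a weaker inhibitor), compound 2 gives 1900 nM, level with compound 1 at 1900 nM. The next analogue, compound 3 `COc1cc(-c2cccc3nc(-c4ccco4)oc23)cc(OC)c1OC`, keeps the shared core and carries furan-2-yl in place of 3-hydroxyphenyl on an aromatic carbon. Within the data shown here, one measured step bears on this change, the exchange of 4-methylphenyl for 3-hydroxyphenyl on the same carbon: no change at the digits printed from compound 1 to compound 2 (within the scatter). That step lies within the scatter. Among the measured compounds shown here, it is only one step, however, and no measured compound has a five-membered aromatic ring at this carbon, so the evidence is thin. No step beyond the scatter is therefore expected in this assay, and no direction is favoured. The expected step is a 1.1-fold higher number from compound 2 to compound 3 (0.02 log units; within the scatter). For compound 3 the estimated value is 2000 nM. The estimated range for compound 3 runs from 700 nM to 6000 nM.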

Compound 3, half-maximal inhibitory concentration: 2600 nM
The estimate for compound 3 lay 1.3-fold (0.11 log units) below the measured number, within the range that was stated.
By their numbers in this assay, from the lowest: compounds 1, 2 and 3 (each within the scatter of the next).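

In this assay furan-2-yl in place of 3-hydroxyphenyl gives a 1.4-fold higher number from compound 2 to compound 3 (0.14 log units; within the scatter) and furan-2-yl in place of 4-methylphenyl gives a 1.4-fold higher number from compound 1 to compound 3 (0.14 log units; within the scatter) at the same aromatic carbon. The earlier pair carried only six-membered aromatic rings of carbon here, so these steps add that a five-membered aromatic ring with one hetero atom also stays within the scatter of both, even with fewer heavy atoms and without the hydrogen-bond donor of 3-hydroxyphenyl. Nothing shown here accounts for this result.

All three compounds carry an aromatic ring at this carbon, so the compounds shown do not say how a carboxylic acid, an amine or a longer alkyl chain would read there. As far as these compounds go, whether any group at this carbon can give a step beyond the scatter remains open.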